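Carbamoyl Swap Carried onto the Methoxybenzyl Core

The compounds below may be only part of what the source reports. "The series", "measured", "known", "first", "only" and "open" are said of these compounds alone.

Compound 1 `CC(C)NC(=O)N1CCN(C(=S)SCc2cn(Cc3ccc(F)cc3)nn2)CC1` and compound 2 `CCN(C)C(=O)N1CCN(C(=S)SCc2cn(Cc3ccc(F)cc3)nn2)CC1` share one core and differ only in ethyl(methyl)amino in place of isopropylamino on a carbonyl carbon. In a functional assay on SMMC-7721 cells (Homo sapiens) for cytotoxicity, read by MTT assay, with a stated time of 72 h (a higher number here means a weaker inhibitor, a lower number a stronger inhibitor), compound 1 gives 5970 nM. In this assay compound 2 gives 23700 nM, and the step is a 4.0-fold higher number from compound 1 to compound 2 (0.60 log units; beyond the scatter). Compound 3 `COc1ccc(Cn2cc(CSC(=S)N3CCN(C(=O)NC(C)C)CC3)nn2)cc1` differs from compound 1 in its core by methoxy in place of fluoro on an aromatic carbon. In this assay compound 3 reaches only a limit, > 128000 nM. The step of an at least 21-fold higher number from compound 1 to compound 3 (1.33 log units; beyond the scatter) therefore rests on that limit, (the limit of > 128000 nM in this assay, at which 1 of the 3 values shown sits). Compound 4 `CCN(C)C(=O)N1CCN(C(=S)SCc2cn(Cc3ccc(OC)cc3)nn2)CC1` carries onto the core of compound 3 the same change, (ethyl(methyl)amino in place of isopropylamino on a carbonyl carbon), at the same place. Beside the earlier step, the expected step is a step that the limit leaves unreadable from compound 3 to compound 4, because the same change gave a 4.0-fold higher number from compound 1 to compound 2 (0.60 log units; beyond the scatter) and compound 3 already stands at the limit of > 128000 nM in this assay, at which 1 of the 3 values shown sits. Compound 4 is thus estimated at 400000 nM, most likely reported again only as a limit.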

Compound 4, half-maximal inhibitory concentration: > 128000 nM
Compound 4 ended at the assay's limit (the forecaster's own chance of this, stated with the estimate: 90%); the middle value is on the limit's open side.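

In this assay compound 4 gives > 128000 nM, which is a limit and not a number. Whether the change to ethyl(methyl)amino carries over from the core of compound 1 to the core of compound 3 therefore cannot be read, because the steps on the core of compound 3 end at that limit: the limit of > 128000 nM in this assay, at which 2 of the 4 values shown sit. Methoxy in place of fluoro on an aromatic carbon gives an at least 5.4-fold higher number from compound 2 to compound 4 (0.73 log units; beyond the scatter), so both pairs run the same way, though their sizes cannot be set against each other: the same change on two cores in this assay, an at least 21-fold higher number (1.33 log units; beyond the scatter) from compound 1 to compound 3 and an at least 5.4-fold higher number (0.73 log units; beyond the scatter) from compound 2 to compound 4; the limit leaves it open whether they differ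

The compounds shown leave open whether any carbamoyl group gives a readable value on the core of compound 3. On these data alone, the effect of pyrrolidine in place of isopropylamino, or of chloro in place of fluoro, also remains open.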